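The compounds below may be only part of what the source reports. "The series", "measured", "known", "first", "only" and "open" are said of these compounds alone.

Compound 1 `O=C(Nc1cccc(-n2cc(-c3ccncc3)c(-c3ccc(Cl)c(O)c3)n2)c1)Nc1ccc(Cl)c(Cl)c1` gives only the assay limit > 32500 nM in a functional assay on UO-31 cells (Homo sapiens) for inhibition, read by sulforhodamine B assay, with a stated time of 48 h; a higher number here means a weaker inhibitor of growth, a lower number a stronger inhibitor of growth.
Compound 2 `COc1cc(-c2nn(-c3cccc(NC(=O)c4ccc(Cl)c(C(F)(F)F)c4)c3)cc2-c2ccncc2)ccc1Cl` likewise gives only the limit > 32500 nM in this assay.

Compound 2 therefore stands at the limit of > 32500 nM in this assay, at which 2 of the 2 values shown sit, with no number of its own. Compound 3 `COc1cc(-c2nn(-c3cccc(NC(=O)c4cccc(C(F)(F)F)c4)c3)cc2-c2ccncc2)ccc1Cl` differs from compound 2 by hydrogen in place of chloro on an aromatic carbon. For the measured compounds named here, no step between two measured compounds is available to size such a change, so in this assay the expected step is none beyond the scatter, in either direction. The step is expected to be a step that the limit leaves unreadable from compound 2 to compound 3. Compound 3 is estimated at 40000 nM, between 15000 nM and 100000 nM, most likely again reported only as a limit.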

Compound 3, concentration for total growth inhibition: > 50000 nM
Compound 3: only a limit was reported; the forecaster's own chance of this, stated with the estimate: 75%; middle value at least 1.2-fold (0.09 log units) away from the limit.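

Compound 2 and compound 3 both give only limits in this assay, so no step can be read between them. From the compounds shown here alone, whether going from 4-chloro-3-(trifluoromethyl)phenyl to 3-(trifluoromethyl)phenyl changes growth inhibition at all stays open.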